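The source may report more compounds than this note shows. Statements on the series, on what has been measured and on what is new or still open speak of the compounds shown alone.

Compound 1 `CCCCCC(CCO)n1cnc2c(Cl)ncnc21` gives > 50000 nM in a functional assay on SW480 cells (Homo sapiens) for antiproliferative activity, read by MTT assay, with a stated time of 48 h (a higher number here means a weaker inhibitor, a lower number a stronger inhibitor), and this value is a limit of the assay, not a number. Going by the values given here, compound 2 `CCCCCCCCC[C@H](CCO)n1cnc2c(Cl)ncnc21` gives 1630 nM in this assay, the only actual number so far. Compound 3 `CCCCCCCCCC(CCO)n1cnc2c(Cl)ncnc21` is the next to be read against compound 2. Its structure differs only in stereochemistry: the two compounds have the same atoms and bonds; at least one stereo element is drawn with a configuration in one of them and without one in the other: 1 of 1 stereo elements differ; a stereocentre at a saturated chain carbon is drawn R in compound 2 and without a configuration in compound 3. The two compounds have the same atoms and bonds, and the stereocentre at a saturated chain carbon, drawn R in compound 2, is drawn without a configuration in compound 3. Among the compounds with values here, no measured step covers a change of this kind. In this assay, the expectation is therefore no shift beyond the scatter, with any small shift more likely towards weaker inhibition than compound 2 at 1630 nM. The expected change is a 1.3-fold higher number from compound 2 to compound 3 (0.13 log units; within the scatter). For compound 3 the estimated value is 2200 nM, with an expected range of 1100 nM to 5000 nM.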

Compound 3, half-maximal inhibitory concentration: 1150 nM
Compound 3: the middle estimate sits 1.9-fold (0.28 log units) above what was measured; the range from low to high includes it.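

In this assay, the stereocentre at the saturated chain carbon shows a 1.4-fold lower number from compound 2 to compound 3 (0.15 log units; within the scatter), so the reading does not separate the compound drawn R from the one drawn without a configuration: the fact that one of compounds 2 and 3 is drawn with a defined configuration and the other without, at the place where they differ. The chain change gives the first readable size in the series, with butyl in place of hydrogen on a saturated chain carbon, six bonds along the chain from an aromatic nitrogen, accompanying an at least 43-fold lower number from compound 1 to compound 3 (1.63 log units; beyond the scatter). The value of compound 1, > 50000 nM, is a limit of the assay and not a number: the limit of > 50000 nM in this assay, at which 1 of the 3 values shown sits.

On these data alone, how a form drawn S reads, and whether a longer chain than that of compound 3 moves the value further, stay open. Also open, as far as these compounds go, is what an amine in place of the chlorine or a carboxylic acid in place of the hydroxyl would give.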